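The compounds below may be only part of what the source reports. "The series", "measured", "known", "first", "only" and "open" are said of these compounds alone.

Working notes on the step from compound 3 to compound 4. In an ADME assay on MOLT-3 cells (Homo sapiens) for cytotoxicity, with a stated time of 7 days (a lower number here means that less compound is tolerated, a higher number that more compound is tolerated), compound 3 `CCCCOc1nc(N)nc2c1ncn2/C=C1/CC1(CO)CO` gives > 20000 nM, which is a limit and not a number. Compound 1 `Nc1nc(NCc2ccccc2)c2ncn(/C=C3/CC3(CO)CO)c2n1` gives > 20000 nM, also a limit. For compound 2 `Nc1nc(NC2CCCCC2)c2ncn(/C=C3/CC3(CO)CO)c2n1` the entry reads "not determined" (no result reported). Going by the values given here, the series so far is summed up by the limit of > 20000 nM in this assay, at which 2 of the 3 values shown sit.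

Compound 4 `CCCCNc1nc(N)nc2c1ncn2/C=C1/CC1(CO)CO` carries butylamino in place of butoxy on an aromatic carbon.

Among the compounds with values here, only one measured step bears on this change, and it concerns the same position: a step that the two limits leave unreadable from compound 1 to compound 3. It gives no size to carry over, since both ends are limits. The amino-linked compound 1 and the oxygen-linked compound 3 thus show no readable difference. No step beyond the scatter is therefore expected in this assay, and no direction is favoured. The expected move is a number no higher from compound 3 to compound 4 (the limit leaves the size open). For compound 4 the estimate is 20000 nM, with an expected range from 7000 nM to 40000 nM, and a further limit result is the likeliest outcome.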

Compound 4, half-maximal cytotoxic concentration: > 20000 nM
Compound 4 was reported as a limit; the forecaster's own chance of this, stated with the estimate: 75%; the middle value sits exactly at the limit.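

Compound 4 gives > 20000 nM in this assay, which is a limit, and its steps from compound 1 and compound 3, both also limits, cannot be read. The compounds shown leave open whether benzylamino, butoxy and butylamino on the shared core differ at all in this assay.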